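Swapping a seven-membered ring for a methylated six-membered one

The source may hold more compounds than are shown below. What is called first, only, known or untested is meant among the compounds shown, and "the series" means these compounds.

Three nucleoside amides have been measured in an assay on cell membranes for binding affinity to 2-oxoglutarate receptor 1 (Rattus norvegicus), read by radioligand binding; a lower number here means a stronger inhibitor, a higher number a weaker inhibitor. The parent, compound 1 `NC(=O)[C@H]1OC(n2cnc3c(N)ncnc32)[C@H](O)[C@@H]1O`, carries only hydrogen on its amide nitrogen, and in this assay compound 1 gives 64 nM. Compound 2 `CCCCCCNC(=O)[C@H]1OC(n2cnc3c(N)ncnc32)[C@H](O)[C@@H]1O` adds a hexyl chain there, and in this assay compound 2 gives 19 nM. Compound 3 `Nc1ncnc2c1ncn2C1O[C@H](C(=O)NC2CCCCCC2)[C@@H](O)[C@H]1O` bears a cycloheptyl group instead, and in this assay compound 3 gives 22 nM.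

Among the three numbers, compound 3 sits second highest, yet the move a 1.2-fold higher number from compound 2 to compound 3 (0.06 log units; within the scatter) is within the scatter, so compound 2 and compound 3 cannot be told apart; the move a 2.9-fold lower number from compound 1 to compound 3 (0.46 log units; beyond the scatter) is a modest gain over the parent.

Compound 4 `CC1CCCCC1NC(=O)[C@H]1OC(n2cnc3c(N)ncnc32)[C@H](O)[C@@H]1O` is not yet measured. It differs from compound 3 only in the group on the amide nitrogen: 2-methylcyclohexyl in place of cycloheptyl on an amide-type nitrogen. Among the measured compounds shown here, the steps that bear on this change are a 3.4-fold lower number from compound 1 to compound 2 (0.53 log units; beyond the scatter) and a 2.9-fold lower number from compound 1 to compound 3 (0.46 log units; beyond the scatter), both modest gains from adding a hydrocarbon group of this size, and a 1.2-fold higher number from compound 2 to compound 3 (0.06 log units; within the scatter), which shows that chain or ring made no difference beyond the scatter. Exchanging one seven-carbon ring for another is therefore expected to give a step of a 1.1-fold higher number from compound 3 to compound 4 (0.06 log units; within the scatter), none beyond the scatter. Compound 4 is expected to give about 25 nM in this assay, within a range from 10 nM to 60 nM.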

Compound 4, inhibition constant: 69.5 nM
For compound 4 the middle estimate is 2.8-fold (0.44 log units) below the measured one; the measured number lies above the stated range.
By their numbers in this assay, from the lowest: compounds 2 and 3 (each within the scatter of the next); then compounds 1 and 4 (each within the scatter of the next).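

At the amide nitrogen, the carbon count of the group does not settle the result: in this assay, cycloheptyl and 2-methylcyclohexyl each have seven carbons, yet the exchange gives a 3.2-fold higher number from compound 3 to compound 4 (0.50 log units; beyond the scatter) and the comparison with the open hexyl chain gives a 3.7-fold higher number from compound 2 to compound 4 (0.56 log units; beyond the scatter) as well. The parent carries only hydrogen at this nitrogen, and a 1.1-fold higher number from compound 1 to compound 4 (0.04 log units; within the scatter) leaves compound 4 indistinguishable from it, so the modest gain seen with hexyl and cycloheptyl does not come with every hydrocarbon group of this size. How these carbons are arranged therefore matters here, although nothing shown gives a reason for the weaker binding of compound 4.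

The compounds shown do not separate the contribution of the smaller ring from that of the methyl group, and a plain cyclohexyl group on the same nitrogen would be the direct comparison. They also leave open how far the trend runs for other hydrocarbon groups, such as cyclopentyl or a longer chain like octyl.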